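The source may report more compounds than this note shows. Statements on the series, on what has been measured and on what is new or still open speak of the compounds shown alone.

Measured compounds in an ADME assay on McCoy cells (Mus musculus) for antiproliferative activity, read by sulforhodamine B assay, with a stated time of 48 h; on this read-out lower numbers stand for stronger inhibition and higher numbers for weaker inhibition:
compound 1 `CC1(C)[C@@H]2CC3=NCC(=O)O[C@@]3(C)[C@H]1C2` gives > 900000 nM, a limit of this assay.
compound 2 `CC(C)(C)OC(=O)n1cnc(C[C@H]2N=C3C[C@H]4C[C@H](C4(C)C)[C@@]3(C)OC2=O)c1` gives > 1300000 nM, a limit of this assay.
compound 3 `CC(C)(C)OC(=O)NCCC[C@@H]1N=C2C[C@@H]3C[C@@H](C3(C)C)[C@]2(C)OC1=O` gives > 1200000 nM, a limit of this assay.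

Compound 1 therefore stands only at a limit, and it does not separate from the other two, since all three values shown are limits (the limit of > 900000 nM in this assay, at which 1 of the 3 values shown sits, (the limit of > 1200000 nM in this assay, at which 1 of the 3 values shown sits), (the limit of > 1300000 nM in this assay, at which 1 of the 3 values shown sits)). Compound 4 `CC1(C)[C@H]2CC3=NCC(=O)O[C@]3(C)[C@@H]1C2` is the unmeasured mirror image: the two compounds have the same atoms and bonds and differ only in configuration as drawn: 3 of 3 stereo elements differ (all stereocentres are inverted: mirror images); a stereocentre at a saturated ring carbon is drawn S in compound 1 and R in compound 4; a stereocentre at a saturated ring carbon is drawn S in compound 1 and R in compound 4; a stereocentre at a saturated ring carbon is drawn S in compound 1 and R in compound 4. Going by the values given here, no step between two measured compounds is available, so nothing here shows how inversion of configuration changes the read-out in this assay. Compound 4 is expected to give 900000 nM, with a range from 300000 nM to 3000000 nM. The expected step of a number no higher from compound 1 to compound 4 (the limit leaves the size open) is none beyond the usual scatter, and the read-out is most likely again a limit.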

Compound 4, half-maximal inhibitory concentration: > 2000000 nM
Compound 4 was reported as a limit; the forecaster's own chance of this, stated with the estimate: 85%; middle value at least 2.2-fold (0.34 log units) from the limit.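

In this assay, going by these compounds alone, compound 4 gives > 2000000 nM, a limit; compound 1 also stands only at a limit, so no step between compound 1 and compound 4 can be read. The compounds shown leave open whether inversion of configuration changes the read-out at all.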